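The source may hold more compounds than are shown below. What is called first, only, known or untested is meant among the compounds shown, and "the series" means these compounds.

Working notes on the series.

Compound 1 `NC(=O)c1ccc(-c2cnc(C(O)CCc3ccc(-c4ccccc4)cc3)o2)nc1` carries a hydroxy on the chain between the shared core and the biphenyl. In an assay for inhibition of Fatty-acid amide hydrolase 1 (Rattus norvegicus) (on this read-out lower numbers stand for stronger inhibition and higher numbers for weaker inhibition), compound 1 gives > 1000 nM, which is a limit of the assay rather than a number; the measurement sits at the limit of > 1000 nM in this assay, at which 1 of the 3 values shown sits. Compound 2 `COC(=O)c1ccc(-c2cnc(C(O)CCc3ccc(-c4ccccc4)cc3)o2)nc1` replaces the amide by a methyl ester, and in this assay compound 2 gives 1100 nM. Compound 3 `COC(=O)c1cccc(-c2cnc(C(O)CCc3ccc(-c4ccccc4)cc3)o2)n1` moves the ester to the other position on the pyridine, and in this assay compound 3 gives 9000 nM; the step of an 8.2-fold higher number from compound 2 to compound 3 (0.91 log units; beyond the scatter) is the only readable one here, as a step that the limit leaves unreadable from compound 1 to compound 2 and a step that the limit leaves unreadable from compound 1 to compound 3 start from the limit.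

Compound 4 `NC(=O)c1ccc(-c2cnc(CCCc3ccc(-c4ccccc4)cc3)o2)nc1` differs from compound 1 by hydrogen in place of hydroxy on a saturated chain carbon bound to an aromatic carbon and a saturated chain carbon. Going by the values given here, none of the measured steps touches this place: all of them alter the pyridine substituent, so no measured step bears on the removal of the hydroxy. Compound 1 itself is only bounded, not placed. With the amide held as in compound 1, compound 4 is expected to remain weak in this assay, around 3000 nM (range 700 nM to 20000 nM), a step that the limit leaves unreadable from compound 1 to compound 4 from the bound of compound 1, with a fair chance that only a limit is again reported.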

Compound 4, inhibition constant: 30000 nM
Compound 4: the middle estimate sits 10-fold (1.00 log units) below what was measured, outside the stated range (above it).
By their numbers in this assay, from the lowest: compound 2; then compound 3; then compound 4.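

No new step can be read from compound 1 to compound 4. In this assay compound 1 gives > 1000 nM, which is a limit of the assay and not a number. The compounds shown leave open what size of step hydrogen in place of hydroxy produces.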